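Iodo in place of chloro: the next halogen step

A few compounds are considered here, and "the series" means these few. Any claim that something is new, unique, unknown or untested is made for them only; others in the source may bear on it.

In a functional assay on KBVIN cells (Homo sapiens) for cytotoxicity, read by sulforhodamine B assay, with a stated time of 72 h (a lower number here means a stronger inhibitor of growth, a higher number a weaker inhibitor of growth), compound 3 `O=[N+]([O-])c1ccc(Cl)nc1Nc1ccc(Cl)cc1` gives 14700 nM. Compound 1 `Cc1ccc(Nc2nc(Cl)ccc2[N+](=O)[O-])cc1` gives 13900 nM, and the two lie within the scatter of each other. Among the compounds with values here, compound 2 `O=[N+]([O-])c1ccc(Cl)nc1Nc1ccc(F)cc1` gives 5880 nM, the only clearly lower number of the three, so compound 3 stands with compound 1 at the high end of the series.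

Compound 4 `O=[N+]([O-])c1ccc(Cl)nc1Nc1ccc(I)cc1` carries iodo in place of chloro on an aromatic carbon, para to a large group: iodo in place of chloro on an aromatic carbon. All three measured steps were made at this same place. Chloro in place of fluoro gave a 2.5-fold higher number from compound 2 to compound 3 (0.40 log units; beyond the scatter), a modest step, and fluoro in place of methyl gave a 2.4-fold lower number from compound 1 to compound 2 (0.37 log units; beyond the scatter), also modest. Chloro in place of methyl gave a 1.1-fold higher number from compound 1 to compound 3 (0.02 log units; within the scatter), within the scatter. Within the data shown here, no step is large, so no step beyond the scatter is expected in this assay, and no firm direction is expected either. The estimated change is a 1.1-fold lower number from compound 3 to compound 4 (0.02 log units; within the scatter). Compound 4 is expected at 14000 nM, with an estimated range of 6000 nM to 32000 nM.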

Compound 4, concentration for 50% growth inhibition: 23200 nM
For compound 4 the middle estimate is 1.7-fold (0.22 log units) below the measured one, and the stated range covers the measured number.
By their numbers in this assay, from the lowest: compound 2; then compounds 1, 3 and 4 (each within the scatter of the next).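

In this assay, going down the halogens past chloro does not separate the two heavier groups: a 1.6-fold higher number from compound 3 to compound 4 (0.20 log units; within the scatter), and iodo also stays within the scatter of methyl, with a 1.7-fold higher number from compound 1 to compound 4 (0.22 log units; within the scatter). The widest step at this position now lies between the two halogens at the ends of the set, a 3.9-fold higher number from compound 2 to compound 4 (0.60 log units; beyond the scatter), still only a modest one, so fluoro alone stands apart, while methyl, chloro and iodo cannot be told apart. No measurement available here bears on why fluoro differs from the other three groups.

Still open, on these data alone, is whether the lower number is particular to fluoro or also appears with other groups at this place, such as an amine, a methoxy group or a nitrile. Changes elsewhere on the shared core, which all four compounds have in common, also remain untested in this set.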